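From an acid-bearing alkene to a methylamide on the shared core

The source may report more compounds than this note shows. Statements on the series, on what has been measured and on what is new or still open speak of the compounds shown alone.

Of the compounds shown here, two built on the same core have been measured in an assay on a protein complex for inhibition of CDK8/Cyclin C (Homo sapiens), with a stated time of 1 h, tested at 10 uM; a higher number here means more inhibition at the concentration tested (going by the name of the read-out), a lower number less inhibition. Compound 1 `NNC(=O)COc1ccncc1-c1ccc2ccccc2c1` carries an (aminocarbamoyl)methoxy group and gives 19%. Compound 2 `O=C(O)/C=C/c1ccncc1-c1ccc2ccccc2c1` carries a 2-carboxyethenyl group in its place and gives 102%, which is the higher of the two numbers; the step of a number 83 percentage points higher from compound 1 to compound 2 (beyond the scatter) is large. Compound 3 `CNC(=O)CCc1ccncc1-c1ccc2ccccc2c1` is the next compound, and the change from compound 2 is 2-(methylcarbamoyl)ethyl in place of 2-carboxyethenyl on an aromatic carbon. Within the data shown here, the only step measured so far, from compound 1 to compound 2, shows that swapping the group at this position can move this assay by a great deal; no step has yet tested the 2-(methylcarbamoyl)ethyl group itself. Among the measured compounds shown here, since the only group that gave a high number is the 2-carboxyethenyl, and it now leaves, a downward step of considerable size is expected, though with wide uncertainty. Compound 3 is therefore estimated to give 45% in this assay, between 10% and 85%, meaning an expected step of a number 57 percentage points lower from compound 2 to compound 3 (beyond the scatter).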

Compound 3, a percentage reported as inhibition, at one concentration (the size of the read-out at that concentration, not a potency): 100%
For compound 3 the middle estimate is 55 percentage points below the measured one; measured number above the stated range.
By their numbers in this assay, from the lowest: compound 1; then compounds 3 and 2 (each within the scatter of the next).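

Replacing the 2-carboxyethenyl group with the 2-(methylcarbamoyl)ethyl group gives a number 2 percentage points lower from compound 2 to compound 3 (within the scatter) in this assay, so a high number at this position does not require the carboxylic acid or the carbon-carbon double bond of that group. A carbamoyl group in the side chain is not enough by itself, however: the (aminocarbamoyl)methoxy group and the 2-(methylcarbamoyl)ethyl group both hold one, yet the change between them gives a number 81 percentage points higher from compound 1 to compound 3 (beyond the scatter), with only the latter pair of compounds differing in this one place and the high number belonging to the second. Nothing measured here explains why these groups give such different or such similar numbers.

Because this read-out comes from a single concentration and is not a potency, it cannot show whether compound 2 and compound 3 would still match at lower concentrations, where a real difference between them might appear. The shown compounds also leave open how a plain amine, a saturated chain ending in a carboxylic acid, or a longer chain ending in the same methylamide would behave at this position on the shared core.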